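The source may report more compounds than this note shows. Statements on the series, on what has been measured and on what is new or still open speak of the compounds shown alone.

Compound 1, with the structure `CNC(=O)c1ccc(Oc2cccc(NC(=S)Nc3ccc(C)cc3)c2)nc1`, carries a 4-methylphenyl group on an amide-type nitrogen. In a functional assay on PC-3 cells (Homo sapiens) for antiproliferative activity, read by MTT assay (on this read-out lower numbers stand for stronger inhibition and higher numbers for weaker inhibition), compound 1 gives a limit, > 100000 nM, rather than a number. Compound 2, `CNC(=O)c1ccc(Oc2cccc(NC(=S)Nc3ccc(F)c(F)c3)c2)nc1`, differs from compound 1 only in that 3,4-difluorophenyl replaces 4-methylphenyl on that amide-type nitrogen. In this assay compound 2 gives 23100 nM. The step between them, an at least 4.3-fold lower number from compound 1 to compound 2 (0.63 log units; beyond the scatter), is the only measured change among these compounds, and it can be stated only as a minimum due to the limit of > 100000 nM in this assay, at which 1 of the 2 values shown sits. Compound 3, `CNC(=O)c1ccc(Oc2cccc(NC(=S)Nc3ccc(OC(F)(F)F)cc3)c2)nc1`, is the compound still to be measured. It differs from compound 1 by trifluoromethoxy in place of methyl on an aromatic carbon. For the measured compounds named here, the one step that bears on it shows that trading the methyl on that ring for a fluorine-bearing substituent brought the number down from the limit to a measured value. A step in the same direction is therefore expected for compound 3, an at least 3.3-fold lower number from compound 1 to compound 3 (0.52 log units; beyond the scatter). Compound 3 is estimated to give 30000 nM in this assay, with a range from 8000 nM to 150000 nM.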

Compound 3, half-maximal inhibitory concentration: > 100000 nM
Compound 3 ended at the assay's limit (the forecaster's own chance of this, stated with the estimate: 30%); middle value at least 3.3-fold (0.52 log units) away from the limit.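

In this assay compound 3, like compound 1, ends at a limit rather than a number, so no step between these two compounds can be read, due to what they share: the limit of > 100000 nM in this assay, at which 2 of the 3 values shown sit.

Going by these compounds, whether trifluoromethoxy in place of methyl changes the activity at all, and in which direction, stays open.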